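An Oxime Ether in Place of an Ethyl Group

A few compounds are considered here, and "the series" means these few. Any claim that something is new, unique, unknown or untested is made for them only; others in the source may bear on it.

Measured compounds:
Compound 1, `CCc1ccc2oc(CSc3nnc(CNc4ccccc4)n3CC)nc2c1`, gives > 1000 nM in an assay on isolated protein for inhibition of long-chain fatty acid transport protein 1 (Homo sapiens); a higher number here means a weaker inhibitor, a lower number a stronger inhibitor; this is a limit of the assay, not a number.
Compound 2, `CCn1c(CNc2ccccc2)nnc1SCC(=O)Nc1ccc(C(=O)OC)cc1`, gives 540 nM in this assay.

In this assay compound 1 stands only at a limit, with no number of its own, while compound 2 has a measured value. For the measured compounds named here, no step between compounds that differ in one place is available, so no sizes of change are known here.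

Compound 3, `CC/C(=N/OC)c1ccc2oc(CSc3nnc(CNc4ccccc4)n3CC)nc2c1`, differs from compound 1 in one place: a group of 6 heavy atoms (4 carbon, 1 nitrogen, 1 oxygen; no ring) in place of a group of 2 heavy atoms (2 carbon; no ring), on an aromatic carbon. Nothing in the data shows how such a change acts on this assay, so any expectation rests on compound 1 alone, which gives only a limit, (the limit of > 1000 nM in this assay, at which 1 of the 2 values shown sits). The step from compound 1 to compound 3 is therefore expected to be small or none beyond the scatter, an at least 1.1-fold lower number from compound 1 to compound 3 (0.04 log units; that floor lies within the scatter). Compound 3 is estimated at 900 nM, with a range from 200 nM to 4000 nM.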

Compound 3, half-maximal inhibitory concentration: > 1000 nM
Compound 3 gave a limit, no number; the forecaster's own chance of this, stated with the estimate: 45%; middle value at least 1.1-fold (0.04 log units) from the limit.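

Compound 3 gives > 1000 nM in this assay, which is a limit and not a number, and compound 1 also stands at a limit, so no step between them can be read: the limit of > 1000 nM in this assay, at which 2 of the 3 values shown sit.

From the compounds shown here alone, how far either compound lies past that limit, and whether the oxime ether in place of the ethyl group changes inhibition at all, stays open.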